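Dropping the Methoxy Group from Compound 1

The source may report more compounds than this note shows. Statements on the series, on what has been measured and on what is new or still open speak of the compounds shown alone.

Compound 1 `COc1ccc(C(F)(F)F)cc1Nc1ncc(C(F)(F)F)c(N2Cc3cccc(N(C)S(C)(=O)=O)c3C2)n1` is one of three compounds sharing a core and tested in a functional assay on HepG2 cells (Homo sapiens) for antiproliferative activity, read by spectrophotometry, with a stated time of 2 days; on this read-out lower numbers stand for stronger inhibition of growth and higher numbers for weaker inhibition of growth. In this assay compound 1 gives only a limit of the assay, > 30000 nM. Compound 2 `COc1cc(Nc2ncc(C(F)(F)F)c(N3Cc4cccc(N(C)S(C)(=O)=O)c4C3)n2)c(OC)cc1Cl` gives 25600 nM in this assay, and compound 3 `COc1cc(Nc2ncc(C(F)(F)F)c(N3Cc4cccc(N(C)S(C)(=O)=O)c4C3)n2)cc(C(F)(F)F)c1` gives 22100 nM. The steps of an at least 1.1-fold lower number from compound 1 to compound 2 (0.06 log units; that floor lies within the scatter) and an at least 1.3-fold lower number from compound 1 to compound 3 (0.13 log units; that floor lies within the scatter) have floors that lie within the scatter, so where compound 1 stands is told only by the limit (the limit of > 30000 nM in this assay, at which 1 of the 3 values shown sits). Compound 4 `CN(c1cccc2c1CN(c1nc(Nc3cccc(C(F)(F)F)c3)ncc1C(F)(F)F)C2)S(C)(=O)=O` differs from compound 1 in one place: hydrogen in place of methoxy on an aromatic carbon. Among the compounds with values here, no measured step removes this methoxy group; the two measured steps that start from compound 1 alter the same part of the molecule and reach only numbers close to the limit. The step of a number no higher from compound 1 to compound 4 (the limit leaves the size open) is therefore expected to be small, with compound 4 estimated to sit near the limit in this assay. Compound 4 is expected at 30000 nM, within a range of 12000 nM to 75000 nM.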

Compound 4, concentration for 50% growth inhibition: > 30000 nM
Compound 4: only a limit was reported; the forecaster's own chance of this, stated with the estimate: 50%; the middle value lies on the limit itself.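

Like compound 1, compound 4 gives only a limit in this assay: > 30000 nM. The step between these two compounds cannot be read, because both sit at that limit: the limit of > 30000 nM in this assay, at which 2 of the 4 values shown sit. Taking the methoxy group off altogether therefore gives no readable gain in growth inhibition, and the two readable comparisons agree, since an at least 1.3-fold higher number from compound 3 to compound 4 (0.13 log units; that floor lies within the scatter) and an at least 1.1-fold higher number from compound 2 to compound 4 (0.06 log units; that floor lies within the scatter) both have floors that lie within the scatter and show no real change.

Going by these compounds, all four compounds sit at or close to the limit, so what this aromatic carbon can contribute remains open. On these data alone, it is still unknown whether an amine or a carboxylic acid on this carbon would give a value clear of the limit in this assay.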